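The source may hold more compounds than are shown below. What is called first, only, known or untested is meant among the compounds shown, and "the series" means these compounds.

Compound 2 `COc1cc2c(Nc3ccc(Cl)cc3)ncnc2c(OC)c1OC` gives 31000 nM in a functional assay on PC-3 cells (Homo sapiens) for inhibition, read by MTT assay, with a stated time of 72 h (on this read-out lower numbers stand for stronger inhibition and higher numbers for weaker inhibition), the highest of the three numbers recorded. Its nearest neighbour is compound 1 `COc1cc2c(Nc3cccc([N+](=O)[O-])c3)ncnc2c(OC)c1OC`, which in this assay gives 24400 nM; the furthest is compound 3 `COc1cc2c(Nc3ccc(O)cc3)ncnc2c(OC)c1OC`, which in this assay gives 20100 nM, and both gaps lie within the scatter. Going by the values given here, the single measured step, a 1.5-fold lower number from compound 2 to compound 3 (0.19 log units; within the scatter), is likewise within the scatter. Compound 4 `COc1cc2c(Nc3ccc(Br)cc3)ncnc2c(OC)c1OC` differs from compound 2 by bromo in place of chloro on an aromatic carbon. Among the compounds with values here, no measured step exchanges one halogen for another, and all three numbers sit close together. Compound 4 is therefore expected to show a 1.1-fold lower number from compound 2 to compound 4 (0.04 log units; within the scatter), nothing beyond the scatter. The estimated value of compound 4 in this assay is 28000 nM, with a range from 14000 nM to 56000 nM.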

Compound 4, half-maximal inhibitory concentration: 23400 nM
Compound 4: the middle estimate sits 1.2-fold (0.08 log units) above what was measured, and the stated range covers the measured number.
By their numbers in this assay, from the lowest: compounds 3, 4, 1 and 2 (each within the scatter of the next).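

In this assay, the exchange of one halogen for another at this position now has a measured step, a 1.3-fold lower number from compound 2 to compound 4 (0.12 log units; within the scatter), and it changes nothing that can be read. The step from hydroxy to bromo at the same place, a 1.2-fold higher number from compound 3 to compound 4 (0.07 log units; within the scatter), also stays inside the scatter, so chloro, bromo and hydroxy on this aromatic carbon cannot be told apart on this read-out. No measured evidence bears on why this is so.

The compounds shown leave open whether an amine, a carboxylic acid or a longer chain at this position would move the number beyond the scatter.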